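The compounds below may be only part of what the source reports. "The series", "measured", "known", "first", "only" and "open" are said of these compounds alone.

In a functional assay on HepG2 cells (Homo sapiens) for cytotoxicity, read by MTT assay, with a stated time of 48 h (a higher number here means a weaker inhibitor, a lower number a stronger inhibitor), compound 2 `CNC(=O)CSc1nc2ccc(NC(=O)c3ccccc3)cc2s1` gives 26500 nM, the highest of the three numbers measured. Compound 1 `CNC(=O)CSc1nc2ccc(NC(=O)c3ccccc3OC)cc2s1` gives 18500 nM in this assay, and the step of a 1.4-fold higher number from compound 1 to compound 2 (0.16 log units; within the scatter) stays within the scatter. Compound 3 `CNC(=O)CSc1nc2ccc(NC(=O)CCl)cc2s1` gives 1900 nM in this assay; the step of a 14-fold lower number from compound 2 to compound 3 (1.14 log units; beyond the scatter) is the only large one among the three, and the step of a 9.7-fold lower number from compound 1 to compound 3 (0.99 log units; beyond the scatter) points the same way.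

Compound 4 `COc1ccc(CNC(=O)CSc2nc3ccc(NC(=O)c4ccccc4)cc3s2)cc1` has not yet been measured. It differs from compound 2 in one place: 4-methoxyphenyl in place of hydrogen on a saturated chain carbon bound to an amide-type nitrogen, so that methyl becomes 4-methoxybenzyl and methylamino becomes (4-methoxybenzyl)amino. Every measured step concerns the other amide of the shared core, at its carbonyl carbon or at an aromatic carbon; none touches the chain carbon changed here. No measured step therefore bears on this change, and there is no ground for expecting a step beyond the scatter in either direction, though the width of the expectation is wide for that reason.

Compound 4 is accordingly expected to give about 20000 nM in this assay. The range for compound 4 is estimated to run from 5000 nM to 60000 nM. The expected step of a 1.3-fold lower number from compound 2 to compound 4 (0.12 log units; within the scatter) is thus small.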

Compound 4, half-maximal inhibitory concentration: 12700 nM
Compound 4: the middle estimate sits 1.6-fold (0.20 log units) above what was measured, and the stated range covers the measured number.
By their numbers in this assay, from the lowest: compound 3; then compounds 4, 1 and 2 (each within the scatter of the next, the first and the last beyond it).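

In this assay, going by these compounds alone, the saturated chain carbon bound to an amide-type nitrogen, which no earlier step touched, turns out to respond to substitution: 4-methoxyphenyl in place of hydrogen there gives a 2.1-fold lower number from compound 2 to compound 4 (0.32 log units; beyond the scatter), a modest move towards a stronger inhibitor. Adding this group of 8 heavy atoms therefore does not cost activity in this assay, at least on the phenyl amide of compound 2. The step remains modest, whereas a 14-fold lower number from compound 2 to compound 3 (1.14 log units; beyond the scatter), a change at the carbonyl carbon of the other amide, is large, and no measured evidence explains the effect of the 4-methoxybenzyl group.

The compounds shown leave open whether the step belongs to the aromatic ring or to its methoxy group, and a plain benzyl group, a longer chain carrying a phenyl ring or a chain ending in an amine at this place would help to separate these. They also leave open whether 4-methoxybenzyl would give a step of similar size and direction on a core carrying the chloromethyl amide of compound 3.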